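Phenyl for methyl at the acyl position of compound 3

This account rests on a few compounds, and the source may have more. Where it says the series, first, only, none or still open, it means among the compounds named here.

Of the compounds shown here, three that share one core have been measured in an assay on isolated protein for inhibition of Nitric oxide synthase, inducible (Homo sapiens), read by scintillation counting, with a stated time of 30 min, tested at 50 uM; a higher number here means more inhibition at the concentration tested (going by the name of the read-out), a lower number less inhibition. Compound 1 `COc1ccc(N)c(C2=NN(C(=O)C3CC3)C(C)(C)S2)c1` gives 90.1%, compound 2 `COc1ccc(N)c(C2=NN(C(=O)C3CCC3)C(C)(C)S2)c1` gives 57.8%, and compound 3 `CC(=O)N1N=C(c2cc(Cl)ccc2N)SC1(C)C` gives 72.8%. Compound 3 therefore stands second of the three numbers: its value is beyond the scatter above that of compound 2 and beyond the scatter below that of compound 1.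

Compound 4 `CC1(C)SC(c2cc(Cl)ccc2N)=NN1C(=O)c1ccccc1` has not yet been measured in this assay. It differs from compound 3 in a single place: phenyl in place of methyl on a carbonyl carbon. Among the compounds with values here, the one measured step that bears on this change is the one from compound 1 to compound 2, where a larger group replaced a smaller one on the carbonyl carbon and inhibition fell by a number 32.3 percentage points lower from compound 1 to compound 2 (beyond the scatter), a large step beyond the scatter. Growth at this position has so far been accompanied by lower inhibition, and the change from methyl to phenyl is a still larger one, so a step downward beyond the scatter in this assay is expected for compound 4, though its size rests on a single precedent and remains uncertain. Compound 4 is estimated to give 45%, with a plausible range from 15% to 75%, an expected step of a number 27.8 percentage points lower from compound 3 to compound 4 (beyond the scatter).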

Compound 4, a percentage reported as inhibition, at one concentration (the size of the read-out at that concentration, not a potency): 20.8%
The estimate for compound 4 lay 24.2 percentage points above the measured number, and the stated range covers the measured number.
By their numbers in this assay, from the lowest: compound 4; then compound 2; then compound 3; then compound 1.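

In this assay, the change from methyl to phenyl on a carbonyl carbon whose other neighbour is the amide-type nitrogen in a ring gives a number 52 percentage points lower from compound 3 to compound 4 (beyond the scatter), the first view of an aromatic ring at this place. The earlier fall, a number 32.3 percentage points lower from compound 1 to compound 2 (beyond the scatter), came from a swap between two saturated rings on compounds carrying a methoxy group, whereas this one appears on compounds carrying chlorine, so a larger acyl group goes with lower inhibition in both pairs shown, and neither pair goes against this. Nothing available explains the fall, and the numbers alone give no reason for it.

The compounds shown leave open whether the loss follows the aromatic ring itself or simply the larger group, a question that a cyclohexyl group or a longer chain such as n-butyl on the same carbonyl carbon would address. They also leave open how cyclopropyl, the acyl group of compound 1 at 90.1%, would behave on the chlorine-bearing compounds, and whether an amine or a carboxylic acid on the phenyl ring of compound 4 would change its inhibition.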